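Compound 3: carbamoylmethyl in place of 2-hydroxyethyl

The source may report more compounds than this note shows. Statements on the series, on what has been measured and on what is new or still open speak of the compounds shown alone.

Compound 1 (`FC(F)(F)Oc1ccc(Nc2ncnc3c2cnn3C2CCCCC2)cc1`) carries cyclohexyl on an aromatic nitrogen, and in an ADME assay on BaF3 cells (Mus musculus) for cytotoxicity (a lower number here means that less compound is needed, a higher number that more compound is needed for the effect), compound 1 gives 9300 nM as its half-maximal effective concentration. Compound 2 (`OCCn1ncc2c(Nc3ccc(OC(F)(F)F)cc3)ncnc21`) carries 2-hydroxyethyl in that place. Compound 2 reads > 10000 nM in this assay and that value is a limit of the assay, not a number. Compound 2 therefore sits at the limit of > 10000 nM in this assay, at which 1 of the 2 values shown sits, and no exact position can be given. The measured step is an at least 1.0-fold higher number from compound 1 to compound 2 (0.03 log units; that floor lies within the scatter) and it gives a floor, not a size.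

Compound 3 (`NC(=O)Cn1ncc2c(Nc3ccc(OC(F)(F)F)cc3)ncnc21`) differs from compound 2 in one place (carbamoyl in place of hydroxymethyl on a saturated chain carbon bound to an aromatic nitrogen): carbamoyl in place of hydroxymethyl on a saturated chain carbon bound to an aromatic nitrogen, which also reads 2-hydroxyethyl to carbamoylmethyl. Resting on an at least 1.0-fold higher number from compound 1 to compound 2 (0.03 log units; that floor lies within the scatter) as the only measured step at that place, no step beyond the scatter is expected in this assay in either direction. The expected change is a step that the limit leaves unreadable from compound 2 to compound 3 and a report as a limit is also expected. For compound 3 the estimated value is 12000 nM (expected range 6000 nM to 25000 nM).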

Compound 3, half-maximal effective concentration: 3300 nM
Compound 3: the middle estimate sits 3.6-fold (0.56 log units) above what was measured; measured number outside the range, below it.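

Carbamoyl in place of hydroxymethyl on a saturated chain carbon bound to an aromatic nitrogen gives an at least 3.0-fold lower number from compound 2 to compound 3 (0.48 log units; beyond the scatter) in this assay and so provides the first step at this place that clears the scatter. Carbamoylmethyl in place of cyclohexyl on an aromatic nitrogen gives a 2.8-fold lower number from compound 1 to compound 3 (0.45 log units; beyond the scatter) and confirms, from a pair with two exact values, that the group on this nitrogen can shift the number toward less compound needed for the effect, which the floor between compound 1 and compound 2 could not show. The step from the hydroxyethyl compound remains a floor and gives no size, because compound 2 stands at a limit: the limit of > 10000 nM in this assay, at which 1 of the 3 values shown sits.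

On these data alone, whether a carboxylic acid, a methyl ester or a dimethyl amide on the same chain carbon would follow the carbamoyl group in this assay stays open, as does a longer chain ending in carbamoyl. With compound 3 as the only exact reading below the limit among the small chains shown, the part of the carbamoyl group that matters here cannot yet be separated out.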